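Dropping the Methoxy Group: What the Vero Numbers Suggest

The compounds below may be only part of what the source reports. "The series", "measured", "known", "first", "only" and "open" are said of these compounds alone.

Of the compounds shown here, two have so far been measured in an ADME assay on Vero cells (Chlorocebus sabaeus) for cytotoxicity; a higher number here means a weaker inhibitor, a lower number a stronger inhibitor. In this assay compound 1 `COC(=O)c1c(C)[n+]([O-])c2ccc(C)cc2[n+]1[O-]` gives > 62.5 ug/mL, which is a limit of the assay and not a number. For the measured compounds named here, compound 2 `COC(=O)c1c(C)[n+]([O-])c2ccc(OC)cc2[n+]1[O-]` is the one compound with an actual number: in this assay compound 2 gives 52.6 ug/mL. Going by the values given here, the single measured step, an at least 1.1-fold lower number from compound 1 to compound 2 (0.07 log units; that floor lies within the scatter), lies within the scatter, and because the limit of > 62.5 ug/mL in this assay, at which 1 of the 2 values shown sits, caps the value of compound 1, even its direction is uncertain.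

Compound 3 `COC(=O)c1c(C)[n+]([O-])c2ccccc2[n+]1[O-]` differs from compound 2 by hydrogen in place of methoxy on an aromatic carbon. Among the compounds with values here, the only step that bears on this change is the methyl-to-methoxy step, which showed no movement beyond the scatter, so the expected step of a 1.1-fold higher number from compound 2 to compound 3 (0.04 log units; within the scatter) is none beyond the scatter. Compound 3 is therefore estimated to give about 58 ug/mL in this assay, within a range from 30 ug/mL to 120 ug/mL, with a real chance that only the limit is reported.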

Compound 3, half-maximal inhibitory concentration: > 10 ug/mL
Compound 3: a limit, no number; the forecaster's own chance of this, stated with the estimate: 45%; the middle value lies beyond the limit too.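

In this assay compound 3 gives > 10 ug/mL, which is a limit of the assay and not a number. Its steps from compound 2 and from compound 1 therefore cannot be read. The compounds shown leave open whether hydrogen in place of methoxy on an aromatic carbon changes the number in this assay.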